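The compounds below may be only part of what the source reports. "The series", "measured", "known", "first", "only" and "open" are said of these compounds alone.

Of the compounds shown here, three from one series have been measured in a functional assay on LoVo cells (Homo sapiens) for inhibition, read by MTT assay, with a stated time of 72 h; on this read-out lower numbers stand for stronger inhibition and higher numbers for weaker inhibition. Compound 1 `Cc1noc(C)c1-c1cnc(N)c(Oc2ccc(C(=O)Nc3ncccc3Cl)cc2)n1` gives 14800 nM. Compound 2 `Cn1cc(-c2cnc(N)c(Oc3ccc(C(=O)Nc4cccc(Cl)c4)cc3)n2)cn1` gives 24500 nM, and compound 3 `Cn1cc(-c2cnc(N)c(Oc3ccc(C(=O)Nc4cccc(Cl)n4)cc3)n2)cn1` gives 48600 nM, the highest of the three numbers. The step of a 2.0-fold higher number from compound 2 to compound 3 (0.30 log units; within the scatter) lies within the scatter, so compound 2 and compound 3 cannot be told apart on this read-out; compound 1 stands beyond the scatter from compound 3, with the lower number.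

Compound 4 `Cn1cc(-c2cnc(N)c(Oc3ccc(C(=O)Nc4ncccc4Cl)cc3)n2)cn1` has not yet been measured. It differs from compound 3 in one place: 3-chloropyridin-2-yl in place of 6-chloropyridin-2-yl on an amide-type nitrogen. Going by the values given here, no measured step covers exactly this swap. Among the compounds with values here, the one measured step at the same position, a 2.0-fold higher number from compound 2 to compound 3 (0.30 log units; within the scatter), is within the scatter, which suggests that changes to the amide-bound ring leave little trace here. Compound 1 carries the same 3-chloropyridin-2-yl group as compound 4, yet it also differs from compound 3 in the group on the shared core, so the pair compound 1 and compound 3 is not a clean step. For compound 4 a modest move toward a lower number is expected, a 1.9-fold lower number from compound 3 to compound 4 (0.29 log units; within the scatter), leaning on the lower value of compound 1, 14800 nM. Compound 4 is therefore estimated at 25000 nM in this assay, within a range from 9000 nM to 70000 nM.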

Compound 4, half-maximal inhibitory concentration: 16500 nM
For compound 4 the middle estimate is 1.5-fold (0.18 log units) above the measured one; low and high end bracket the measured number.
By their numbers in this assay, from the lowest: compounds 1, 4, 2 and 3 (each within the scatter of the next, the first and the last beyond it).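

In this assay the amide-bound ring now gives a readable step: the 3-chloropyridin-2-yl and 6-chloropyridin-2-yl groups hold the same atoms, joined differently, and they can be told apart, with a 2.9-fold lower number from compound 3 to compound 4 (0.47 log units; beyond the scatter) for this swap on the amide-type nitrogen. Other swaps leave no readable trace, as 3-chloropyridin-2-yl cannot be told apart from 3-chlorophenyl, with a 1.5-fold lower number from compound 2 to compound 4 (0.17 log units; within the scatter) on that same nitrogen, and 1-methyl-1H-pyrazol-4-yl cannot be told apart from 3,5-dimethyl-1,2-oxazol-4-yl on the aromatic carbon, with a 1.1-fold higher number from compound 1 to compound 4 (0.05 log units; within the scatter) for that swap. Nothing available here explains why the two chloropyridin-2-yl groups differ in this read-out.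

The compounds shown leave open whether the same swap between the two chloropyridin-2-yl groups would give a similar step with 3,5-dimethyl-1,2-oxazol-4-yl on the shared core, as only one such pair can be read. They also leave open what a methoxy group or an amine in place of the chlorine on the pyridin-2-yl ring would do to the number in this assay on this nitrogen.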